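This account rests on a few compounds, and the source may have more. Where it says the series, first, only, none or still open, it means among the compounds named here.

Measured compounds in an assay on U2OS cells for activation of nuclear factor erythroid 2-related factor 2 (Homo sapiens), read by chemiluminescence, with a stated time of 6 h; on this read-out higher numbers stand for an effect only at larger amounts of compound and lower numbers for an effect already at smaller amounts:

Compound 1 `COc1ccccc1S(=O)(=O)/C=C/c1cccnc1` gives > 10000 nM, which is a limit of the assay rather than a number.
Compound 2 `COc1cccc(S(=O)(=O)/C=C/c2cccnc2)c1` gives 6290 nM.
Compound 3 `COc1ccccc1S(=O)(=O)/C=C/c1ccncc1` gives 1520 nM.

Compounds 1 and 3 share a core and differ in one place: pyridin-4-yl in place of pyridin-3-yl on a double-bonded chain carbon bound to a double-bonded chain carbon. That change gives an at least 6.5-fold lower number from compound 1 to compound 3 (0.81 log units; beyond the scatter), a step whose stated size rests on (the limit of > 10000 nM in this assay, at which 1 of the 3 values shown sits), so it is a lower bound on the true movement. Compound 2 carries a different core; the difference between the two cores is not broken down here. Among the numbers that are not limits, compound 2 sits highest, and compound 3 is its nearest neighbour.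

Compound 4 `COc1cccc(S(=O)(=O)/C=C/c2ccncc2)c1` has not yet been measured in this assay. It relates to compound 2 as compound 3 relates to compound 1: pyridin-4-yl in place of pyridin-3-yl on a double-bonded chain carbon bound to a double-bonded chain carbon, at the same place, so this is the same change. Should it carry over, a step of about a 7.0-fold lower number from compound 2 to compound 4 (0.84 log units; beyond the scatter) is expected, resting on an at least 6.5-fold lower number from compound 1 to compound 3 (0.81 log units; beyond the scatter). On that basis compound 4 is estimated at 900 nM, with a likely range from 250 nM to 3200 nM.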

Compound 4, half-maximal effective concentration: 655 nM
For compound 4 the middle estimate is 1.4-fold (0.14 log units) above the measured one; the range from low to high includes it.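

In this assay, pyridin-4-yl in place of pyridin-3-yl on the core of compound 2 gives a 9.6-fold lower number from compound 2 to compound 4 (0.98 log units; beyond the scatter) and so moves the number the same way as on the core of compound 1, which means the direction of the change carried over on both cores shown. Two cores cannot establish a rule for the whole series, and whether the change has the same size on both remains unsettled: the same change on two cores in this assay, an at least 6.5-fold lower number (0.81 log units; beyond the scatter) from compound 1 to compound 3 and a 9.6-fold lower number (0.98 log units; beyond the scatter) from compound 2 to compound 4; the limit leaves it open whether they differ. Compound 1 gives > 10000 nM and this is a limit of the assay, not a number, so the earlier step cannot be pinned to one size.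

The compounds shown leave open how pyridin-2-yl would compare with the two pyridine attachments tested, placed on the same double-bonded chain carbon. They also leave open whether the same change would still lower the number on a core that carries an amine or a carboxylic acid.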